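The compounds below may be only part of what the source reports. "The series", "measured", "known", "first", "only" and "open" are said of these compounds alone.

Compound 1 `COc1ccc(CNc2nc3cc(N)cc(N)c3nc2-c2ccccc2)cc1OC` gives 4270 nM in a functional assay on M14 cells (Homo sapiens) for inhibition, read by sulforhodamine B assay, with a stated time of 48 h; on this read-out higher numbers stand for weaker inhibition of growth and lower numbers for stronger inhibition of growth.
Compound 2 `Nc1cc(N)c2nc(-c3ccccc3)c(NCc3ccc(F)cc3)nc2c1` gives 23400 nM in this assay.

Going by the values given here, of the two numbers at hand, compound 2 gives the higher one; its nearest neighbour is compound 1, and the only measured step runs between them: a 5.5-fold higher number from compound 1 to compound 2 (0.74 log units; beyond the scatter). That step swaps one aryl group for another on the saturated chain carbon, and it is the whole of what has been measured in this assay.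

Compound 3 `Nc1cc(N)c2nc(-c3ccccc3)c(Sc3ccc(F)cc3)nc2c1` has not yet been tested. It differs from compound 2 in one place: (4-fluorophenyl)sulfanyl in place of (4-fluorobenzyl)amino on an aromatic carbon. The amino group and the chain carbon that carried the fluorophenyl group are gone, and the fluorophenyl group now hangs from a sulfur atom directly on the aromatic carbon.

Among the compounds with values here, no measured step touches this kind of change; the one step known concerns the aryl group on the chain, not the linker itself. The expectation for this assay therefore rests on compound 2 alone, and the step of a 1.2-fold lower number from compound 2 to compound 3 (0.07 log units; within the scatter) is estimated to be small, with no direction beyond the scatter. Compound 3 is thus expected to give about 20000 nM in this assay, within a broad range from 5000 nM to 80000 nM.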

Compound 3, concentration for 50% growth inhibition: 15800 nM
Beside the measured number, compound 3's estimate is 1.3-fold (0.10 log units) above it; low and high end bracket the measured number.
By their numbers in this assay, from the lowest: compound 1; then compounds 3 and 2 (each within the scatter of the next).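

At this aromatic carbon, (4-fluorophenyl)sulfanyl in place of (4-fluorobenzyl)amino gives a 1.5-fold lower number from compound 2 to compound 3 (0.17 log units; within the scatter) in this assay and so leaves no readable difference. The earlier step changed only the aryl group on the chain, whereas this one changes the link to the shared core: the amino group, with its hydrogen-bond donor, and the chain carbon both leave, and sulfur enters. In this one pair, the 4-fluorophenyl group can therefore hang from either link with no change in growth inhibition that stands clear of the scatter, and no supporting measurement is available to explain why the two links read alike.

On these data alone, in this pair, the sulfur arrives at the same moment as the chain carbon leaves, so the effect of each alone remains open; a benzylsulfanyl group or a 4-fluorophenoxy group at this carbon would begin to separate them. Also open, as far as these compounds go, is whether the 3,4-dimethoxyphenyl group, which marks the step of a 5.5-fold higher number from compound 1 to compound 2 (0.74 log units; beyond the scatter) on the amino link, would behave in the same way on the sulfur link.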